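Carboxy for Cyano on a Diaryl Urea: Clearance Expectation

The source may hold more compounds than are shown below. What is called first, only, known or untested is meant among the compounds shown, and "the series" means these compounds.

compound 1 `N#Cc1ccc(NC(=O)Nc2ccc(F)c(C(F)(F)F)c2)cc1`: 12 uL/min
compound 2 `Cc1cc(NC(=O)Nc2ccc(F)c(C(F)(F)F)c2)on1`: 108 uL/min
compound 3 `O=C(Nc1cccnc1)Nc1ccc(F)c(C(F)(F)F)c1`: 154 uL/min

In an ADME assay on microsomes from liver (Mus musculus) for metabolic stability, using NADPH, with a stated time of 60 min (a higher number here means faster removal of the compound, a lower number slower removal), compound 1 gives 12 uL/min. That is the lowest of the three numbers measured: compound 2 gives 108 uL/min and compound 3 gives 154 uL/min, and the gaps from compound 1 to each of them lie beyond the scatter. Among the measured compounds shown here, the one step measured between neighbours, a 1.4-fold higher number from compound 2 to compound 3 (0.15 log units; within the scatter), exchanges the ring on an amide-type nitrogen and leaves the six-membered aromatic ring of carbon only untouched, so it says nothing about the change now in question.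

Compound 4 `O=C(Nc1ccc(C(=O)O)cc1)Nc1ccc(F)c(C(F)(F)F)c1` differs from compound 1 in one place: carboxy in place of cyano on an aromatic carbon. For the measured compounds named here, no measured pair in this set varies the group at that position, so the data give no step on which to build a direction. Compound 4 is therefore expected to give 10 uL/min in this assay, with a range from 4 uL/min to 30 uL/min, which amounts to an expected step of a 1.2-fold lower number from compound 1 to compound 4 (0.08 log units; within the scatter) and rests only on the value of compound 1.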

Compound 4, intrinsic clearance in a liver preparation (reported as CLH), per the amount of preparation that the assay uses: < 7 uL/min
Compound 4 ended at the assay's limit (the forecaster's own chance of this, stated with the estimate: 5%); middle value at least 1.4-fold (0.15 log units) away from the limit.
By their numbers in this assay, from the lowest: compound 1; then compounds 2 and 3 (each within the scatter of the next). At a limit, below all of these: compound 4.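

In this assay, among the compounds shown here, the exchange of carboxy for cyano on an aromatic carbon, para to a large group, gives an at least 1.7-fold lower number from compound 1 to compound 4 (0.23 log units; that floor lies within the scatter), the first step in this set that varies the group at this position. Compound 4 stands at a limit of the assay and not at a number: the limit of < 7 uL/min in this assay, at which 1 of the 4 values shown sits. The step thus has a floor but no measured size, and although that floor lies within the scatter, it shows that carboxy at this position brings no rise from the already low number of compound 1.

From the compounds shown here alone, how far the true value of compound 4 lies under its limit remains open. So does how the number would move with an amine, a primary amide or a methyl ester at this position, groups that would show whether the result is particular to carboxy.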